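The compounds below may be only part of what the source reports. "The series", "measured", "known", "first", "only" and "open" are said of these compounds alone.

Compound 1 `COc1cc(-c2nn(-c3cccc(NC(=O)Nc4ccc(Cl)c(Cl)c4)c3)cc2-c2ccncc2)ccc1Cl` was tested in a functional assay on SK-MEL-2 cells (Homo sapiens) for inhibition, read by sulforhodamine B assay, with a stated time of 48 h (on this read-out lower numbers stand for stronger inhibition of growth and higher numbers for weaker inhibition of growth), and gave 2350 nM. Its one measured companion, compound 2 `O=C(Nc1cccc(-n2cc(-c3ccncc3)c(-c3ccc(Cl)c(O)c3)n2)c1)Nc1ccc(Cl)c(Cl)c1`, gave 2640 nM in this assay. Among the measured compounds shown here, compound 1 holds the lower of the two numbers recorded, but the only step that separates them, a 1.1-fold higher number from compound 1 to compound 2 (0.05 log units; within the scatter), lies within the scatter, so the two compounds cannot be told apart on potency.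

Compound 3 `COc1cc(-c2nn(-c3cccc(NC(=O)Nc4ccc(Cl)c(C(F)(F)F)c4)c3)cc2-c2ccncc2)ccc1Cl` has not yet been measured. It differs from compound 1 in one place: trifluoromethyl in place of chloro on an aromatic carbon. For the measured compounds named here, no measured step in this set touches that part of the molecule; the single step from compound 1 to compound 2 concerns a different position and was itself within the scatter. There is therefore nothing in the data to argue for a shift in either direction, and the expectation for compound 3 rests on compound 1 alone.

On that basis, compound 3 is expected to give about 2350 nM in this assay, somewhere between 900 nM and 6000 nM, which amounts to an expected step of no change at the digits printed from compound 1 to compound 3 (within the scatter).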

Compound 3, concentration for total growth inhibition: 2580 nM
For compound 3 the middle estimate is 1.1-fold (0.04 log units) below the measured one, and the stated range covers the measured number.
By their numbers in this assay, from the lowest: compounds 1, 3 and 2 (each within the scatter of the next).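

Among the compounds shown, only compound 3 alters the aromatic ring that carries the two chloro groups in compound 1, and going from 3,4-dichlorophenyl to 4-chloro-3-(trifluoromethyl)phenyl in this assay gives a 1.1-fold higher number from compound 1 to compound 3 (0.04 log units; within the scatter) as the step. At this position, ortho to the remaining chloro group, trifluoromethyl with 4 heavy atoms can therefore stand in place of chloro with 1 heavy atom, and the measurement cannot tell the two compounds apart. No measured information is available that would account for this result.

Going by these compounds, this single swap does not show how far the position can be pushed, so it remains open whether a group of another kind, such as an amine or a carboxylic acid, or simply hydrogen, would also stay within the scatter of compound 1. It is also open whether trifluoromethyl at this position, combined with hydrogen in place of methyl on the oxygen as in compound 2, would give a number that could be told apart from those of the three compounds shown.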